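The compounds below may be only part of what the source reports. "The series", "measured", "known", "first", "only" and "open" are said of these compounds alone.

Measured in a functional assay on blood (Homo sapiens) for inhibition; a higher number here means a weaker inhibitor, a lower number a stronger inhibitor:
- Compound 1 `Oc1ccc(OCc2ccc3ccccc3n2)cc1C1(c2ccccc2)CCCC1`: 1920 nM
- Compound 2 `COC(=O)COc1ccc(OCc2ccc3ccccc3n2)cc1C1(c2ccccc2)CCCC1`: 890 nM
- Compound 3 `O=C(Nc1cccnc1)Oc1ccc(OCc2ccc3ccccc3n2)cc1C1(c2ccccc2)CCCC1`: 52 nM

Compound 2 holds the second highest of these three numbers, with a 2.2-fold lower number from compound 1 to compound 2 (0.33 log units; beyond the scatter) and a 17-fold lower number from compound 2 to compound 3 (1.23 log units; beyond the scatter). Compound 4 `COC(=O)COc1ccc(OCc2ccc3ccccc3n2)cc1C1(c2ccccc2)CCCCC1` differs from it by 1-phenylcyclohexyl in place of 1-phenylcyclopentyl on an aromatic carbon, with 1-phenylcyclohexyl in place of 1-phenylcyclopentyl on an aromatic carbon, ortho to a (methoxycarbonyl)methoxy group. The measured steps, a 2.2-fold lower number from compound 1 to compound 2 (0.33 log units; beyond the scatter) and a 37-fold lower number from compound 1 to compound 3 (1.57 log units; beyond the scatter), both change the group on the oxygen, as does the step between compound 2 and compound 3, and none alters the 1-phenylcyclopentyl group. They therefore give no direct guide, and no step beyond the scatter is expected in this assay. The expected step is a 1.0-fold higher number from compound 2 to compound 4 (0.00 log units; within the scatter). Compound 4 is estimated at 900 nM, within an expected range of 350 nM to 2300 nM.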

Compound 4, half-maximal inhibitory concentration: 200 nM
Beside the measured number, compound 4's estimate is 4.5-fold (0.65 log units) above it; measured number below the stated range.
By their numbers in this assay, from the lowest: compound 3; then compound 4; then compound 2; then compound 1.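

With 1-phenylcyclohexyl in place of 1-phenylcyclopentyl on the aromatic carbon and the (methoxycarbonyl)methoxy group unchanged, this assay gives a 4.5-fold lower number from compound 2 to compound 4 (0.65 log units; beyond the scatter). Going by these compounds alone, the earlier steps changed only the group on the oxygen, so this is the first sign that the number also responds to the size of the non-aromatic ring at this position. No evidence on hand bears on this step.

Going by these compounds, it remains open whether the same change holds with the (pyridin-3-yl)carbamoyl group of compound 3 or the hydrogen of compound 1 on the oxygen. On these data alone, it is also open how a seven-membered carbon ring or a piperidine ring would fare here.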